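A few compounds are considered here, and "the series" means these few. Any claim that something is new, unique, unknown or untested is made for them only; others in the source may bear on it.

The measured compounds in a functional assay on HL-60 cells (Homo sapiens) for cytotoxicity, read by trypan blue exclusion, with a stated time of 48 h (a lower number here means that less compound is tolerated, a higher number that more compound is tolerated), are:

compound 1 `COc1ccc(/C=C2\CN(C(=O)CCSCCS)C/C(=C\c3ccc(OC)cc3)C2=O)cc1` with 3370 nM
compound 2 `O=C1/C(=C/c2ccccc2)CN(C(=O)CCSCCO)C/C1=C\c1ccccc1` with 1530 nM
compound 3 `O=C1/C(=C/c2ccc(Cl)cc2)CN(C(=O)CCSCCS(=O)(=O)O)C/C1=C\c1ccc(Cl)cc1` with 29700 nM

Among these three, compound 1 stands second highest. Its nearest neighbour is compound 2, whose number is lower by a margin that lies beyond the usual scatter, so compound 2 is tolerated less than compound 1. Compound 3 stands much higher than compound 1, again beyond the scatter, and is the compound of which the most is tolerated.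

Compound 4 `COc1ccc(/C=C2\CN(C(=O)CCSCCO)C/C(=C\c3ccc(OC)cc3)C2=O)cc1` has not yet been measured. It keeps the shared core of compound 1 and differs from it in one place: hydroxy in place of sulfanyl on a saturated chain carbon, two bonds along the chain from a sulfur. Going by the values given here, no pair of measured compounds differing only in this way is available, so the size of the step is uncertain. Among the compounds with values here, the only compound carrying the hydroxy chain, compound 2, gives a lower number than compound 1, but it also differs at the aryl rings, so it offers only a hint.

Compound 4 is expected to stay close to compound 1, perhaps a little lower, a step of a 1.3-fold lower number from compound 1 to compound 4 (0.13 log units; within the scatter) that may well remain within the scatter. The estimate for compound 4 in this assay is therefore 2500 nM, with a range from 1000 nM to 6500 nM.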

Compound 4, half-maximal cytotoxic concentration: 2670 nM
Compound 4: the middle estimate sits 1.1-fold (0.03 log units) below what was measured; low and high end bracket the measured number.
By their numbers in this assay, from the lowest: compounds 2, 4 and 1 (each within the scatter of the next, the first and the last beyond it); then compound 3.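

In this assay, hydroxy in place of sulfanyl on a saturated chain carbon, two bonds along the chain from a sulfur, gives a 1.3-fold lower number from compound 1 to compound 4 (0.10 log units; within the scatter) with the rest of the molecule unchanged. Going by these compounds alone, this is the first reading of the change on its own, which the earlier compounds could only hint at, and this one pair shows no measurable difference between 2-sulfanylethyl and 2-hydroxyethyl at this place. Nothing measured here explains why the two compounds read alike.

As far as these compounds go, it remains open whether an amine, a carboxylic acid or a longer chain at this place would also stay close to compound 1. The compounds shown also leave open whether the same change gives a similar step with the aryl groups of compound 2 or compound 3.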